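The source may hold more compounds than are shown below. What is called first, only, known or untested is meant among the compounds shown, and "the series" means these compounds.

In a functional assay on SEM cells (Homo sapiens) for cytotoxicity, with a stated time of 72 h (a lower number here means that less compound is needed, a higher number that more compound is needed for the effect), compound 1 `C=C[C@@](C)(/C=C/c1ccc(O)cc1)CC/C=C(\C)C=O` gives > 36600 nM as a limit of the assay, not a number. Compound 2 `C=C[C@@](C)(/C=C/c1ccc(O)c(/C=C/C(=O)OCC)c1)CCC=C(C)C` gives > 36600 nM as a limit too. Compound 3 `CCOC(=O)/C=C/c1cc(/C=C/[C@](C)(/C=C/c2ccc(OC)cc2)CCC=C(C)C)ccc1O` gives > 36600 nM and this is again only a limit. Within the data shown here, the whole series so far therefore comes down to the limit of > 36600 nM in this assay, at which 3 of the 3 values shown sit, and offers no readable number.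

Compound 4 `COc1ccc(/C=C/[C@@](C)(/C=C/c2ccc(O)c(/C=C/C(C)=O)c2)CCC=C(C)C)cc1` departs from compound 3 by one change, methyl in place of ethoxy on a carbonyl carbon which turns 2-(ethoxycarbonyl)ethenyl into 2-acetylethenyl.

Among the measured compounds shown here, only one measured step exists, and it offers little guidance. Putting 2-(4-methoxyphenyl)ethenyl in place of vinyl gives a step that the two limits leave unreadable from compound 2 to compound 3 and has no size to carry over. That step also leaves the ethoxy group untouched, so no measurement speaks directly to this change.

With compound 3 at > 36600 nM as a limit, the likeliest expectation is that compound 4 will also return only a limit. The expected size is an at least 1.2-fold lower number from compound 3 to compound 4 (0.08 log units; that floor lies within the scatter) as a rough estimate, with no firmly supported direction. Compound 4 is estimated at 30000 nM with an expected range from 8000 nM to 60000 nM should the assay report a number at all.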

Compound 4, half-maximal effective concentration: 8670 nM
For compound 4 the middle estimate is 3.5-fold (0.54 log units) above the measured one, within the range that was stated.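

In this assay, among these compounds, methyl in place of ethoxy on a carbonyl carbon, which turns 2-(ethoxycarbonyl)ethenyl into 2-acetylethenyl, gives an at least 4.2-fold lower number from compound 3 to compound 4 (0.62 log units; beyond the scatter), the first step with a readable size. Compound 3 gives > 36600 nM, which is only a limit, so this size is a floor and not a full measure of the change. Compound 4 is also the only compound shown that comes away from the limit holding the others: the limit of > 36600 nM in this assay, at which 3 of the 4 values shown sit.

Going by these compounds, the earlier step from vinyl to 2-(4-methoxyphenyl)ethenyl cannot be read, so it remains open whether the methyl change would have the same effect with vinyl in that place, as the change is seen here on one background only. On these data alone, it is also open how far the result depends on what sits on this carbonyl carbon, since a longer chain such as propyl, an amine or a hydroxyl that makes a carboxylic acid would show whether methyl is a special case or one point on a wider trend.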